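The compounds below may be only part of what the source reports. "The series", "measured", "known", "first", "only" and "open" are said of these compounds alone.

In a functional assay on the whole organism (strain albino) for inhibition, with Rattus norvegicus as the target, read by paw edema, with stated times of 30 min and 2 h, at a dose of 100 mg/kg by the oral route (on this read-out higher numbers stand for more inhibition at the one dose given (going by the name of the read-out) and lower numbers for less inhibition), compound 1 `CC(Br)C(=O)Nc1ccc(C(=O)/C=C/c2ccc(Cl)cc2)cc1` gives 45%. Compound 2 `COc1ccc(/C=C/C(=O)c2ccc(NC(=O)C(C)Br)cc2)cc1` differs from compound 1 in one place, (methoxy in place of chloro on an aromatic carbon), and in this assay compound 2 gives 40%, so that this change made a step of a number 5 percentage points lower from compound 1 to compound 2 (within the scatter). Compound 3 `CC(=O)c1ccc(OCC(=O)Nc2ccc(C(=O)/C=C/c3ccc(Cl)cc3)cc2)cc1` carries a different core; the difference between the two cores is not broken down here. In this assay compound 3 gives 52%, a number whose gap to compound 1 lies within the scatter while its gap to compound 2 lies beyond it. Compound 4 `COc1ccc(/C=C/C(=O)c2ccc(NC(=O)COc3ccc(C(C)=O)cc3)cc2)cc1` is not yet measured and differs from compound 3 by methoxy in place of chloro on an aromatic carbon, the same change that was made from compound 1 to compound 2. Because that earlier step was a number 5 percentage points lower from compound 1 to compound 2 (within the scatter), the new step is expected to be of similar size, a number 5 percentage points lower from compound 3 to compound 4 (within the scatter), again within the scatter. Compound 4 is therefore estimated at 47%, with a likely range from 37% to 57%.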

Compound 4, a percentage reported as inhibition, in the whole organism at one dose (the size of the read-out at that dose, not a potency): 35%
Estimate against measurement, compound 4: 12 percentage points above; measured number outside the range, below it.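

Methoxy in place of chloro gives, in this assay, a number 17 percentage points lower from compound 3 to compound 4 (beyond the scatter). Set beside the earlier step, the size on the two cores cannot be told apart: the same change on two cores in this assay, a number 5 percentage points lower (within the scatter) from compound 1 to compound 2 and a number 17 percentage points lower (beyond the scatter) from compound 3 to compound 4, 12 percentage points apart, within the scatter of two such steps. The change thus points the same way on both cores, but this does not show that the core alters the size of the step, nor that the size stays fixed, and two pairs are a thin basis for carrying it to any further core.

The compounds shown leave open how other groups in this place on the aromatic ring would read, such as an amine or a carboxylic acid. They also leave open whether a longer chain in place of methoxy would follow the same direction.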